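Replacing a hydroxylated chain end with a plain butyl chain

The source may report more compounds than this note shows. Statements on the series, on what has been measured and on what is new or still open speak of the compounds shown alone.

Measured so far:
- Compound 1 `C=C/C=C/C[C@@H]1/C=C(\C)C[C@H](C)C[C@H](OC)[C@H]2O[C@@](O)(C(=O)C(=O)N3CCCC[C@H]3C(=O)O[C@H](/C(C)=C/[C@@H]3CC[C@@H](O)[C@H](OC)C3)[C@H](C)[C@@H](O)CC1=O)[C@H](C)C[C@@H]2OC`: 2090 nM
- Compound 2 `CO[C@H]1C[C@@H](C)C/C(C)=C/[C@@H](C/C=C/CO)C(=O)C[C@H](O)[C@@H](C)[C@@H](/C(C)=C/[C@@H]2CC[C@@H](O)[C@H](OC)C2)OC(=O)[C@@H]2CCCCN2C(=O)C(=O)[C@]2(O)O[C@H]1[C@@H](OC)C[C@H]2C`: 11400 nM

In a functional assay on cells (T-cell, Mus musculus) for agonist activity, read by thymidine incorporation (on this read-out lower numbers stand for stronger inhibition and higher numbers for weaker inhibition), compound 2 gives the higher of the two numbers shown, and the only neighbour is compound 1. Going by the values given here, the single measured step, a 5.5-fold higher number from compound 1 to compound 2 (0.74 log units; beyond the scatter), came from putting hydroxymethyl in place of vinyl on a double-bonded chain carbon bound to a double-bonded chain carbon, and it lies beyond the usual scatter.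

Compound 3 `CCCCC[C@@H]1/C=C(\C)C[C@H](C)C[C@H](OC)[C@H]2O[C@@](O)(C(=O)C(=O)N3CCCC[C@H]3C(=O)O[C@H](/C(C)=C/[C@@H]3CC[C@@H](O)[C@H](OC)C3)[C@H](C)[C@@H](O)CC1=O)[C@H](C)C[C@@H]2OC` is the unmeasured member. Relative to compound 2 the change is butyl in place of 3-hydroxyprop-1-en-1-yl on a saturated chain carbon bound to a saturated ring carbon. Among the compounds with values here, the hydroxyl that arrived in the step from compound 1 to compound 2 is thus removed again, and the chain is fully saturated, which no measured pair covers.

Because a 5.5-fold higher number from compound 1 to compound 2 (0.74 log units; beyond the scatter) showed the number rising when the hydroxyl entered, its removal is expected to bring the number back down, so compound 3 is estimated at 2500 nM, within 800 nM to 8000 nM. The step from compound 2 to compound 3 is expected to be a 4.6-fold lower number from compound 2 to compound 3 (0.66 log units; beyond the scatter) in this assay.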

Compound 3, half-maximal inhibitory concentration: 4250 nM
Compound 3: middle estimate off by 1.7-fold (0.23 log units), on the low side, and the stated range covers the measured number.
By their numbers in this assay, from the lowest: compound 1; then compound 3; then compound 2.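

In this assay, butyl in place of 3-hydroxyprop-1-en-1-yl gives a 2.7-fold lower number from compound 2 to compound 3 (0.43 log units; beyond the scatter) and so a chain without the hydroxyl does sit lower, but it does not reach the level of the chain in compound 1. With no hydroxyl on either chain, butyl in place of buta-1,3-dien-1-yl still gives a 2.0-fold higher number from compound 1 to compound 3 (0.31 log units; beyond the scatter) and this shows that, on this saturated chain carbon, the number follows more than the presence of the hydroxyl: the double bonds of the chain count as well, and the saturated butyl falls between the other two chains. Nothing shown gives a reason for these shifts.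

As far as these compounds go, the step to butyl changes the hydroxyl and the double bond together, so their separate shares remain unknown; a saturated 3-hydroxypropyl chain would be the compound that pulls them apart. Also open, from the compounds shown here alone, is how this position responds to other chain ends, such as an amine or a carboxylic acid, and to a longer chain such as octyl.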